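Adding a second (chloromethyl)carbonyl to compound 1

The source may hold more compounds than are shown below. What is called first, only, known or untested is meant among the compounds shown, and "the series" means these compounds.

Among the measured compounds shown here, in a functional assay on A-431 cells (Homo sapiens) for antiproliferative activity (a higher number here means a weaker inhibitor, a lower number a stronger inhibitor), compound 1 `CO[C@@H]1[C@H](OC(=O)NC(=O)CCl)CO[C@]2(COC(C)(C)O2)[C@@]1(O)C1(C)CO1` gives 84000 nM, the only actual number so far. Compound 2 `CO[C@@H]1[C@H](OC(=O)NC(=O)c2ccccc2)CO[C@]2(COC(C)(C)O2)[C@@]1(O)C1(C)CO1` gives > 500000 nM, which is a limit of the assay and not a number. The change to compound 3 `CO[C@@H]1[C@H](OC(=O)NC(=O)CCl)CO[C@]2(COC(C)(C)O2)[C@@]1(OC(=O)CCl)C1(C)CO1` is (chloromethyl)carbonyl in place of hydrogen on an oxygen on a saturated carbon, turning hydroxy into ((chloromethyl)carbonyl)oxy. For the measured compounds named here, only one measured step bears on this, and only indirectly: an at least 5.9-fold higher number from compound 1 to compound 2 (0.77 log units; beyond the scatter). That step replaces chloromethyl with phenyl on a carbonyl carbon, so it removes a chloromethyl group and lies at a different place from the new change. Compound 3 keeps that chloromethyl and gains another, so a modest move to a lower number in this assay is expected, with little certainty. The expected change is a 2.4-fold lower number from compound 1 to compound 3 (0.38 log units; beyond the scatter). For compound 3 the estimated value is 35000 nM, with an expected range of 6000 nM to 150000 nM.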

Compound 3, half-maximal inhibitory concentration: 38000 nM
Compound 3: middle estimate off by 1.1-fold (0.04 log units), on the low side; the range from low to high includes it.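

At the hydroxy position, the change to ((chloromethyl)carbonyl)oxy is tolerated in this assay and gives a 2.2-fold lower number from compound 1 to compound 3 (0.34 log units; beyond the scatter). Unlike the earlier step at the carbonyl carbon, this one joins two actual numbers, so its size can be read directly. It also shows that the hydroxy hydrogen at this position is not required for a measurable value in this assay. Nothing among the data shown accounts for the step.

Whether the lower number depends on the chlorine stays open: the compounds shown include no plain acetyl ester, longer acyl chain, methyl ether or amine at this position. Also open is whether ((chloromethyl)carbonyl)oxy has a similar effect when phenyl replaces the first chloromethyl, as no compound shown combines the two.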